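Para substituent on the pendant phenyl of the diaryl-aminopyrimidine series

This account rests on a few compounds, and the source may have more. Where it says the series, first, only, none or still open, it means among the compounds named here.

Measured compounds:
compound 1 `Nc1ncc(-c2ccccc2)c(-c2ccccc2)n1` 32%
compound 2 `Cc1ccc(-c2cnc(N)nc2-c2ccccc2)cc1` 51%
compound 3 `COc1ccc(-c2cnc(N)nc2-c2ccccc2)cc1` 56%

In an assay on CHO cells for displacement of a labelled ligand from adenosine receptor A1 (Homo sapiens), read by scintillation counting, with a stated time of 1 h, tested at 1 uM (on this read-out lower numbers stand for less inhibition and higher numbers for more inhibition at the one concentration tested (going by the name of the read-out)), compound 3 gives 56%, the highest number of the three. The gap to compound 2 is small: a number 5 percentage points higher from compound 2 to compound 3 (within the scatter), so the two cannot be ordered. The gap to compound 1 is larger: a number 24 percentage points higher from compound 1 to compound 3 (beyond the scatter), and compound 2 shows the same pattern against compound 1 with a number 19 percentage points higher from compound 1 to compound 2 (beyond the scatter).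

Compound 4 `Nc1ncc(-c2ccc(C(F)(F)F)cc2)c(-c2ccccc2)n1` differs from compound 3 by trifluoromethyl in place of methoxy on an aromatic carbon. Among the compounds with values here, no measured step exchanges methoxy for trifluoromethyl, so only indirect bearing exists: two different para groups, methyl and methoxy, each gave a modest rise over hydrogen, while the swap between them stayed within the scatter. A third para group is therefore expected to keep inhibition in the same region, with no confident direction; the estimated step is a number 8 percentage points lower from compound 3 to compound 4 (within the scatter), which lies within the scatter. For compound 4 the estimate in this assay is 48%, in the range 28% to 66%.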

Compound 4, a percentage reported as inhibition, at one concentration (the size of the read-out at that concentration, not a potency): 51%
Compound 4: middle estimate off by 3 percentage points, on the low side; measured number inside the range.
By their numbers in this assay, from the lowest: compound 1; then compounds 2, 4 and 3 (each within the scatter of the next).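

In this assay, trifluoromethyl on this aromatic carbon gives the same kind of gain over hydrogen as methyl and methoxy: a number 19 percentage points higher from compound 1 to compound 4 (beyond the scatter). The swaps among the substituted compounds, a number 5 percentage points lower from compound 3 to compound 4 (within the scatter) and no change at the digits printed from compound 2 to compound 4 (within the scatter), leave compound 2, compound 3 and compound 4 unordered, so at this position, replacing methoxy with the larger trifluoromethyl, which has no hydrogen-bond acceptor, produces no readable change. No evidence accounts for this shared gain over hydrogen or for the lack of separation among the three groups.

Going by these compounds, whether an amine, a carboxylic acid or a longer chain at this place would keep the gain over compound 1 remains open. Readings at one concentration also leave open whether compound 2, compound 3 and compound 4 would show a stronger or weaker effect than one another at other concentrations.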